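Swapping a bromo-methoxyphenyl sulfonyl for a methoxyphenyl sulfonyl

The source may report more compounds than this note shows. Statements on the series, on what has been measured and on what is new or still open speak of the compounds shown alone.

Of the compounds shown here, three sharing one core have been tested in a functional assay on DLD-1 cells (Homo sapiens) for cytotoxicity, read by resazurin assay, with a stated time of 48 h; a lower number here means that less compound is needed, a higher number that more compound is needed for the effect. Compound 1 `O=S(=O)(Nc1ccc(-c2nc3cc(NS(=O)(=O)c4ccc(Cl)s4)ccc3o2)cc1)c1ccc(Cl)s1` gives 33000 nM, compound 2 `COc1ccc(S(=O)(=O)Nc2ccc3oc(-c4ccc(NS(=O)(=O)c5cc(F)ccc5OC)cc4)nc3c2)cc1` gives 18000 nM, and compound 3 `COc1ccc(S(=O)(=O)Nc2ccc3oc(-c4ccc(NS(=O)(=O)c5cc(Br)ccc5OC)cc4)nc3c2)cc1` gives 15000 nM. Compound 3 has the lowest number of the three; its gap to compound 2 lies within the scatter, while its gap to compound 1 lies beyond it. Compound 4 `COc1ccc(S(=O)(=O)Nc2ccc(-c3nc4cc(NS(=O)(=O)c5ccc(OC)cc5)ccc4o3)cc2)cc1` differs from compound 3 by 4-methoxyphenyl in place of 5-bromo-2-methoxyphenyl on a sulfonyl sulfur. For the measured compounds named here, the only measured step touching this part of the molecule, a 1.2-fold lower number from compound 2 to compound 3 (0.08 log units; within the scatter), exchanged one halogen for another and stayed within the scatter. Going by the values given here, no step shows removal of the halogen or a shift of the methoxy group. For compound 4 the expectation in this assay is therefore a step of about a 1.2-fold higher number from compound 3 to compound 4 (0.08 log units; within the scatter), not beyond the scatter. Compound 4 is estimated at 18000 nM, with a range from 8000 nM to 40000 nM.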

Compound 4, half-maximal effective concentration: 28000 nM
Estimate against measurement, compound 4: 1.6-fold (0.19 log units) below; low and high end bracket the measured number.
By their numbers in this assay, from the lowest: compounds 3, 2, 4 and 1 (each within the scatter of the next, the first and the last beyond it).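

In this assay, 4-methoxyphenyl on the sulfonyl sulfur gives a 1.9-fold higher number from compound 3 to compound 4 (0.27 log units; within the scatter) in place of 5-bromo-2-methoxyphenyl and a 1.6-fold higher number from compound 2 to compound 4 (0.19 log units; within the scatter) in place of 5-fluoro-2-methoxyphenyl, both within the scatter. So this position tolerates not only a change of halogen but also losing the halogen while the methoxy group changes place, with no readable shift in the number. No measured evidence bears on why these steps stay small.

The two changes come together here, so neither can be read alone. As far as these compounds go, whether an amine or a carboxylic acid on this phenyl ring would shift the number remains open.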